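Changing One Aryl Group on a Growth Inhibitor

The source may report more compounds than this note shows. Statements on the series, on what has been measured and on what is new or still open speak of the compounds shown alone.

In a functional assay on DU-145 cells (Homo sapiens) for inhibition, read by trypan blue exclusion, with a stated time of 96 h (on this read-out higher numbers stand for weaker inhibition of growth and lower numbers for stronger inhibition of growth), three compounds sharing one core have been measured so far. Compound 1 `Cc1ccc(CS/C(=C/c2ccc(F)c(C)c2)C(=O)c2ccc(Cl)cc2)cc1` gives 25000 nM. Compound 2 `Cc1ccc(CS/C(=C/c2ccc(O)c(O)c2O)C(=O)c2ccc(Cl)cc2)cc1` gives 50000 nM. Compound 3 `Cc1ccc(CS/C(=C/c2ccc(Cl)cc2)C(=O)c2ccc(Cl)cc2)cc1` gives 10000 nM, the lowest number of the three and so the strongest inhibition of growth seen yet.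

Compound 4 `Cc1ccc(CS/C(=C/c2ccccc2Br)C(=O)c2ccc(Cl)cc2)cc1` keeps the core and changes one group, on a double-bonded chain carbon bound to a double-bonded chain carbon: 2-bromophenyl in place of 4-chlorophenyl on a double-bonded chain carbon bound to a double-bonded chain carbon. Its number is not yet known.

All three measured steps involve this same place. The first, a 2.5-fold lower number from compound 1 to compound 3 (0.40 log units; beyond the scatter), and the second, a 5.0-fold lower number from compound 2 to compound 3 (0.70 log units; beyond the scatter), are both modest and both end at the 4-chlorophenyl group. The third, a 2.0-fold higher number from compound 1 to compound 2 (0.30 log units; within the scatter), does not separate the other two groups. Among the measured compounds shown here, neither of the two other groups tried here matches 4-chlorophenyl, which suggests a higher number for compound 4, but no measured compound carries 2-bromophenyl, so this evidence is indirect. The expected change is therefore small and stays inside the normal scatter, with an estimated step of a 1.5-fold higher number from compound 3 to compound 4 (0.18 log units; within the scatter). For compound 4 the estimated value is 15000 nM, with an expected range from 6000 nM to 40000 nM.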

Compound 4, concentration for 50% growth inhibition: 10000 nM
For compound 4 the middle estimate is 1.5-fold (0.18 log units) above the measured one, within the range that was stated.
By their numbers in this assay, from the lowest: compounds 3 and 4 (each within the scatter of the next); then compounds 1 and 2 (each within the scatter of the next).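

In this assay, replacing 4-chlorophenyl with 2-bromophenyl gives no change at the digits printed from compound 3 to compound 4 (within the scatter), so this position has now accepted a second halogen-bearing phenyl group with no separation between the two numbers, even though the halogen and its printed ring number both differ. The new group also stands apart from the two weaker groups in the same way as 4-chlorophenyl, with a 5.0-fold lower number from compound 2 to compound 4 (0.70 log units; beyond the scatter) and a 2.5-fold lower number from compound 1 to compound 4 (0.40 log units; beyond the scatter); among these four compounds, the two phenyl groups carrying a single halogen and nothing else have the lowest numbers, while compound 1, whose 4-fluoro-3-methylphenyl group also carries a halogen, does not reach them. No supporting measurement is available to explain why these groups compare as they do.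

The compounds shown leave open how a plain phenyl group with no halogen, or a phenyl group carrying an amine or a carboxylic acid, would compare at this place. They also cannot show whether the identity of the halogen and its ring position each matter, as 4-chlorophenyl and 2-bromophenyl differ in both at once.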